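The compounds below may be only part of what the source reports. "The series", "measured", "known", "first", "only" and "open" are said of these compounds alone.

Measured in a functional assay on MCF7 cells (Homo sapiens) for antiproliferative activity, read by sulforhodamine B assay, with a stated time of 72 h; a lower number here means a stronger inhibitor, a higher number a weaker inhibitor:
Compound 1 `COc1ccc(/C=C2\CCC=CC2=O)c(C)c1`: 1840 nM
Compound 2 `COc1ccc(/C=C2\CCC=CC2=O)cc1[N+](=O)[O-]`: 1680 nM
Compound 3 `COc1cc(/C=C2\CN(C(=O)OCc3ccccc3)C=CC2=O)cc(OC)c1OC`: > 25000 nM

Compound 1 and compound 2 lie within the usual scatter of each other. Compound 3 stands at a limit of the assay and not at a number: > 25000 nM. Compound 4 `COc1cc(/C=C2\CN(S(=O)(=O)c3ccccc3)C=CC2=O)cc(OC)c1OC` carries phenylsulfonyl in place of benzyloxycarbonyl on an amine nitrogen in a ring. Going by the values given here, no measured pair shows the effect of a change in one place, so any forecast is loose. In this assay a moderate step toward stronger inhibition is expected, estimated as an at least 1.7-fold lower number from compound 3 to compound 4 (0.25 log units; that floor lies within the scatter), and a second limit remains quite possible. For compound 4 the estimate is 14000 nM, with an expected range of 3000 nM to 25000 nM.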

Compound 4, half-maximal inhibitory concentration: > 25000 nM
Compound 4: only a limit was reported (the forecaster's own chance of this, stated with the estimate: 40%); middle value at least 1.7-fold (0.25 log units) away from the limit.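

No step can be read from compound 3 to compound 4, as both compounds stand at a limit of the assay: the limit of > 25000 nM in this assay, at which 2 of the 4 values shown sit. The compounds shown leave open whether phenylsulfonyl or benzyloxycarbonyl on the amine nitrogen gives the stronger inhibitor.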